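The source may report more compounds than this note shows. Statements on the series, on what has been measured and on what is new or still open speak of the compounds shown alone.

Working notes on the series. In an ADME assay on cells (Homo sapiens) for cytotoxicity, read by polymerase chain reaction, with a stated time of 3 days (a lower number here means that less compound is tolerated, a higher number that more compound is tolerated), compound 1 `Cc1nc(N)nc(N[C@@H]2C[C@H](CO)[C@@H](O)[C@H]2O)c1-c1nc2cnccc2s1` gives 25000 nM and compound 2 `Cc1nc(NCC2CCN(C)CC2)nc(N[C@@H]2C[C@H](CO)[C@@H](O)[C@H]2O)c1-c1nc2cnccc2s1` gives 25000 nM while compound 3 `Cc1nc(NCc2ccc(OC(F)(F)F)cc2)nc(N[C@@H]2C[C@H](CO)[C@@H](O)[C@H]2O)c1-c1nc2cnccc2s1` gives 25000 nM and so stands level with both. Compound 4 `Cc1ccc([C@@H](C)Nc2nc(C)c(-c3nc4cnccc4s3)c(N[C@@H]3C[C@H](CO)[C@@H](O)[C@H]3O)n2)cc1` comes next, and its difference from compound 3 is 1-(4-methylphenyl)ethyl in place of 4-(trifluoromethoxy)benzyl on a nitrogen on an aromatic ring in the form of 1-(4-methylphenyl)ethyl in place of 4-(trifluoromethoxy)benzyl on a nitrogen on an aromatic ring. Among the compounds with values here, three measured steps bear on this change, namely no change at the digits printed from compound 1 to compound 2 (within the scatter) and no change at the digits printed from compound 1 to compound 3 (within the scatter) and no change at the digits printed from compound 2 to compound 3 (within the scatter) in the group on that nitrogen, and none of them goes beyond the scatter. Within the data shown here, no measured compound has a defined stereocentre in that group, so this feature remains untested. In this assay no step beyond the scatter is therefore expected in either direction, and the expected change is no change at the digits printed from compound 3 to compound 4 (within the scatter) for this pair. The estimated value for compound 4 is 25000 nM with an expected range from 14000 nM to 32000 nM on this reading.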

Compound 4, half-maximal cytotoxic concentration: 25000 nM
Estimate against measurement, compound 4: no gap at the digits printed; low and high end bracket the measured number.
By their numbers in this assay, from the lowest: compounds 1, 2, 3 and 4 (each within the scatter of the next).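

In this assay, the group on the nitrogen now carries a defined stereocentre, and 1-(4-methylphenyl)ethyl in place of 4-(trifluoromethoxy)benzyl gives no change at the digits printed from compound 3 to compound 4 (within the scatter). The comparisons with the two other groups on this nitrogen read the same: no change at the digits printed from compound 2 to compound 4 (within the scatter) and no change at the digits printed from compound 1 to compound 4 (within the scatter). Within the data shown here, at this position, then, a group made only of carbon with one defined stereocentre adds no step beyond the scatter to what the earlier compounds showed. Nothing available accounts for the identical values. The opposite configuration at the stereocentre remains open, so the single form shown cannot speak for the other. Going by these compounds, a carboxylic acid or a primary amine at the end of a longer chain on this nitrogen also remains open, as do changes elsewhere on the shared core.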